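The source may report more compounds than this note shows. Statements on the series, on what has been measured and on what is new or still open speak of the compounds shown alone.

In a functional assay on HepG2 cells (Homo sapiens) for antiproliferative activity, read by MTT assay, with a stated time of 24 h (on this read-out lower numbers stand for stronger inhibition and higher numbers for weaker inhibition), compound 1 `COc1ccc(C(=O)/C=C/c2cccc([N+](=O)[O-])c2)c2c1C=CC(C)(C)O2` gives 2830 nM. Compound 2 `COc1ccc(C(=O)/C=C/c2ccccn2)c2c1C=CC(C)(C)O2` gives 5760 nM in this assay, a change of a 2.0-fold higher number from compound 1 to compound 2 (0.31 log units; beyond the scatter). For compound 3 `COc1ccc(C(=O)/C=C/c2cccs2)c2c1C=CC(C)(C)O2` this assay reports only a limit, > 10000 nM, which is the floor of detection here (the limit of > 10000 nM in this assay, at which 1 of the 3 values shown sits). Compound 4 `COc1ccc(C(=O)/C=C/c2ccc(Cl)c(Cl)c2)c2c1C=CC(C)(C)O2` differs from compound 3 in one place: 3,4-dichlorophenyl in place of thiophen-2-yl on a double-bonded chain carbon bound to a double-bonded chain carbon. Among the compounds with values here, two measured steps bear on this change. Both an at least 3.5-fold higher number from compound 1 to compound 3 (0.54 log units; beyond the scatter) and an at least 1.7-fold higher number from compound 2 to compound 3 (0.23 log units; that floor lies within the scatter) end in thiophen-2-yl and raise the number, so removing thiophen-2-yl is expected to lower it, and the expected step is an at least 3.3-fold lower number from compound 3 to compound 4 (0.52 log units; beyond the scatter). Compound 4 is therefore estimated at 3000 nM, with a range from 1000 nM to 9000 nM.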

Compound 4, half-maximal inhibitory concentration: > 10000 nM
Compound 4 ended at the assay's limit; the forecaster's own chance of this, stated with the estimate: 15%; middle value at least 3.3-fold (0.52 log units) from the limit.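

In this assay compound 4 gives > 10000 nM, which is a limit of the assay. The step between compound 3 and compound 4 cannot be read, since both values are limits, but an at least 3.5-fold higher number from compound 1 to compound 4 (0.54 log units; beyond the scatter) shows that a six-membered aromatic ring of carbon only does not by itself keep the number low at this place, while an at least 1.7-fold higher number from compound 2 to compound 4 (0.23 log units; that floor lies within the scatter) gives a less clear separation. Two of the four groups at this place now end at the same limit: the limit of > 10000 nM in this assay, at which 2 of the 4 values shown sit.

Still open, from the compounds shown here alone, is whether any group here can give a lower number than compound 1 does. Also open, going by these compounds, is what a phenyl ring carrying an amine or a carboxylic acid would give.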